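Aryl variation on the shared core: compound 3 to compound 4

This account rests on a few compounds, and the source may have more. Where it says the series, first, only, none or still open, it means among the compounds named here.

Compound 3 `O=C(O)C1=Cc2ccccc2OC1(OCc1cc(-c2ccc([N+](=O)[O-])cc2)no1)C(F)(F)F` is measured in a functional assay on A549 cells (Homo sapiens) for inhibition, read by MTT assay, with a stated time of 24 h; on this read-out lower numbers stand for stronger inhibition and higher numbers for weaker inhibition. There compound 3 gives > 150000 nM, which is a limit of the assay rather than a number. Compound 1 `O=C(O)C1=Cc2ccccc2OC1(OCc1cc(-c2ccc(F)cc2)no1)C(F)(F)F` in this assay gives > 150000 nM, also a limit. Compound 2 `CCOC(=O)C1=Cc2ccccc2OC1(OCc1cn(CC(=O)Nc2ccccc2Br)nn1)C(F)(F)F` in this assay gives > 150000 nM, again a limit. All three measured values sit at the limit of > 150000 nM in this assay, at which 3 of the 3 values shown sit, so compound 3 stands level with the other two as far as the numbers show, and no ordering among them can be read.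

Compound 4 `O=C(O)C1=Cc2ccccc2OC1(OCc1cc(-c2ccc(F)cc2F)no1)C(F)(F)F` is not yet measured. It differs from compound 3 by 2,4-difluorophenyl in place of 4-nitrophenyl on an aromatic carbon. Among the measured compounds shown here, the one measured step, a step that the two limits leave unreadable from compound 1 to compound 3, gives no readable size, and no measured step concerns 2,4-difluorophenyl at all. Nothing measured therefore points to a change in this assay beyond the scatter, and the most likely outcome for compound 4 is another limit. The step expected from compound 3 to compound 4 is a step that the limit leaves unreadable from compound 3 to compound 4. Compound 4 is estimated at 200000 nM in this assay, with a range from 80000 nM to 600000 nM, most probably reported only as a limit.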

Compound 4, half-maximal inhibitory concentration: > 150000 nM
Compound 4 ended at the assay's limit; the forecaster's own chance of this, stated with the estimate: 85%; the middle value lies beyond the limit too.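

No step from compound 1 or compound 3 to compound 4 can be read in this assay since all these values are limits: the limit of > 150000 nM in this assay, at which 4 of the 4 values shown sit.

The compounds shown leave open whether any aryl variation on the shared core gives a number rather than a limit in this assay and how large such steps would be.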